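The source may hold more compounds than are shown below. What is called first, only, known or untested is meant among the compounds shown, and "the series" means these compounds.

Compounds measured so far:
compound 1 `c1ccc(Oc2cccc(NC3=NCCO3)c2)cc1` gives 9600 nM
compound 2 `O=C(CCl)NC(=O)Nc1ccc(C2CCCCC2)cc1` gives 900 nM
compound 3 `O=C(CCl)NC(=O)Nc1cccc(OC2CCCCC2)c1` gives 2700 nM

In a functional assay on M21 cells (Homo sapiens) for inhibition, read by sulforhodamine B assay, with a stated time of 48 h (on this read-out lower numbers stand for stronger inhibition of growth and higher numbers for weaker inhibition of growth), compound 2 stands at 900 nM as the lowest of the three numbers, which makes it the strongest inhibitor of growth among them. Compound 3 comes nearest at 2700 nM and compound 1 lies furthest at 9600 nM on the same scale, and both gaps to compound 2 lie beyond the scatter.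

The next compound is compound 4 `O=C(CCl)NC(=O)Nc1ccc(Oc2ccccc2)cc1`, which has phenoxy in place of cyclohexyl on an aromatic carbon. For the measured compounds named here, no two measured compounds differ in one place only, so the data hold no direct guide to this change. In this assay a moderate rise in the number is expected, meaning somewhat weaker inhibition of growth, though it may not clear the scatter by much. This expectation rests on compound 2 holding the lowest number at 900 nM so far, with compound 3 at 2700 nM as the nearest number above it. The estimated change is a 2.0-fold higher number from compound 2 to compound 4 (0.30 log units; within the scatter) in the upward direction. For compound 4 the expected value is 1800 nM with a likely range from 700 nM to 5000 nM once it is measured.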

Compound 4, concentration for 50% growth inhibition: 4200 nM
The estimate for compound 4 lay 2.3-fold (0.37 log units) below the measured number, and the stated range covers the measured number.
By their numbers in this assay, from the lowest: compound 2; then compounds 3 and 4 (each within the scatter of the next); then compound 1.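

In this assay, for the compounds shown here, the step of a 4.7-fold higher number from compound 2 to compound 4 (0.67 log units; beyond the scatter) gives the first direct reading of a single change in this set: on this aromatic carbon, para to a group of 8 heavy atoms, phenoxy in place of cyclohexyl weakens inhibition of growth beyond the scatter. The change swaps a non-aromatic ring of carbon only for an aromatic one and also brings in an oxygen that counts as a hydrogen-bond acceptor, and this one step cannot separate these differences from one another. No measurement at hand speaks to why the number rises.

As far as these compounds go, what a plain phenyl group on the same carbon would give stays open, and with it whether the step follows the aromatic ring or the oxygen. Also open, from the compounds shown here alone, is whether an amine or a longer alkyl chain on this carbon would keep the number of compound 2, and whether the same change reads alike on other aromatic carbons of the shared core.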